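Replacing an Amine with a Tosylate on a Weak Core

The source may report more compounds than this note shows. Statements on the series, on what has been measured and on what is new or still open speak of the compounds shown alone.

Compound 1 `N[C@H]1CC[C@H](Nc2c(C(=O)NCc3ccc(Cl)cc3)nc(Br)c3cccnc23)CC1` gives 4000 nM in a functional assay on HCT-116 cells (Homo sapiens) for cytotoxicity, read by MTT assay, with a stated time of 72 h; a higher number here means a weaker inhibitor, a lower number a stronger inhibitor. Compound 2 `C[C@@H](Nc1c(C(=O)NCc2ccc(F)cc2)nc(Br)c2cccnc12)c1ccccc1` returns only a limit in this assay, > 20000 nM, which is a boundary of the measurement and not a number. Compound 3 `Cc1ccc(S(=O)(=O)Oc2c(C(=O)NCc3ccc(F)cc3)nc(Br)c3cccnc23)cc1` differs from compound 2 in one place: ((4-methylphenyl)sulfonyl)oxy in place of (1-phenylethyl)amino on an aromatic carbon. Among the compounds with values here, no measured pair shows how large such a step is, so the direction is not fixed by the data. Given that compound 2 stands at the limit of > 20000 nM in this assay, at which 1 of the 2 values shown sits, compound 3 is expected to remain in the same weak region, with a step of a number no higher from compound 2 to compound 3 (the limit leaves the size open) and an estimated value of 20000 nM, between 5000 nM and 60000 nM.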

Compound 3, half-maximal inhibitory concentration: > 20000 nM
Compound 3: no number, only a limit; the forecaster's own chance of this, stated with the estimate: 55%; the middle value lies on the limit itself.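

Compound 2 and compound 3 both return only a limit in this assay, so the step between them cannot be read. From the compounds shown here alone, how weak each one truly is, and whether swapping (1-phenylethyl)amino for ((4-methylphenyl)sulfonyl)oxy changes anything, stays open.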